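A ring swap on a saturated chain carbon

The source may hold more compounds than are shown below. What is called first, only, known or untested is meant among the compounds shown, and "the series" means these compounds.

Two compounds have a reading so far in an ADME assay on microsomes from liver (Rattus norvegicus) for metabolic stability (a higher number here means that the compound lasts longer, a lower number that the compound disappears faster), and only one of them is an exact number. Compound 1 (`CC(C)C(/C=C1\NC(=O)NC1=O)c1ccc(-c2ccc3cccc(F)c3c2)[nH]c1=O`) gives 1.46 h as that single exact value. Compound 2 (`CCC(/C=C1\OC(=O)NC1=O)(CC)c1ccc(-c2ccc3cccc(F)c3c2)[nH]c1=O`) gives > 3 h as a limit of the assay and not a number. Within the data shown here, compound 1 is therefore the only firm reference point, and no measured step shows how far a structural change can move the half-life here.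

Compound 3 (`CC(C)C(c1ccc(-c2ccc3cccc(F)c3c2)[nH]c1=O)C1NC(=O)NC1=O`) has not yet been measured. Among the measured compounds shown here, it keeps the core of compound 1 and differs from it in one place, by a group of 7 heavy atoms (3 carbon, 2 nitrogen, 2 oxygen; one five-membered non-aromatic ring with 2 hetero atoms) in place of a group of 8 heavy atoms (4 carbon, 2 nitrogen, 2 oxygen; one five-membered non-aromatic ring with 2 hetero atoms), on a saturated chain carbon bound to an aromatic carbon and a saturated chain carbon as the only change. The entering group is 2,5-dioxoimidazolidin-4-yl, and the group that leaves has no common name.

In this assay no step beyond the usual scatter is expected, and no direction is favoured. The step expected is a 1.1-fold higher number from compound 1 to compound 3 (0.04 log units; within the scatter) and so stays within the scatter. For the measured compounds named here, this expectation rests on compound 1 at 1.46 h alone, with no measured step to guide it. For compound 3 the half-life is expected to be 1.6 h as a middle value, with an estimated range from 0.7 h to 3 h around it.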

Compound 3, half-life: 0.145 h
The estimate for compound 3 lay 11-fold (1.04 log units) above the measured number; the whole stated range lies above it.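

At the saturated chain carbon bound to an aromatic carbon and a saturated chain carbon, placing 2,5-dioxoimidazolidin-4-yl in the position of the group of 8 heavy atoms gives a 10-fold lower number from compound 1 to compound 3 (1.00 log units; beyond the scatter) in this assay, so the half-life in this assay responds strongly to a change at this place. The counts of hydrogen-bond donors and acceptors are the same in the two groups, both carry a five-membered non-aromatic ring with 2 hetero atoms, and neither carries a net charge, so none of these features separates compound 1 from compound 3; what does separate them is one carbon and one double bond outside aromatic rings. Nothing available here gives a cause for this step.

This single pair cannot show whether the carbon or the double bond goes with the shorter half-life, since the two differences arrive together in compound 3. It also leaves open how the half-life would respond to a quite different group at the same place, such as a carboxylic acid, an amine or a longer chain.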